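Benzyl for tert-Butyl, Carried to a Second Core

The source may hold more compounds than are shown below. What is called first, only, known or untested is meant among the compounds shown, and "the series" means these compounds.

Compound 1 `CC1=C(C(=O)OC(C)(C)C)C(c2cccs2)NC(=S)N1` and compound 2 `CC1=C(C(=O)OCc2ccccc2)C(c2cccs2)NC(=S)N1` share one core and differ in a single place; compound 3 `CC1=C(C(=O)OC(C)(C)C)C(c2ccco2)NC(=O)N1C` and compound 4 `CC1=C(C(=O)OCc2ccccc2)C(c2ccco2)NC(=O)N1C` share another. In an assay on membranes from HEK293 cells for displacement of a labelled ligand from adenosine receptor A2b (Homo sapiens), read by scintillation counting, with a stated time of 30 min, tested at 1 uM (a higher number here means more inhibition at the concentration tested (going by the name of the read-out), a lower number less inhibition), compound 1 gives 26%, and compound 2 gives 45%. The change between them is benzyl in place of tert-butyl on an oxygen next to a carbonyl group, and it made a step of a number 19 percentage points higher from compound 1 to compound 2 (beyond the scatter).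

In this assay compound 3 gives 26%, level with compound 1 at the digits shown, so that together these two stand lowest of the three measured numbers; compound 2 lies higher than compound 3 by a margin beyond the scatter. How the core of compound 3 differs from the core of compound 1 is not broken down here.

Compound 4 carries onto the core of compound 3 the same change already made from compound 1 to compound 2: benzyl in place of tert-butyl on an oxygen next to a carbonyl group. The place is the same word for word, so the change is the same one, met twice among the four compounds.

For the measured compounds named here, since compound 3 starts where compound 1 does, the one measured precedent is the natural guide. Compound 4 is expected to give about 42% in this assay, within a range from 25% to 60%. This means an expected step of a number 16 percentage points higher from compound 3 to compound 4 (beyond the scatter), set a little below the earlier one because a number 19 percentage points higher from compound 1 to compound 2 (beyond the scatter) was observed on a different core, and a change seen only once cannot be assumed to carry over in full.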

Compound 4, a percentage reported as inhibition, at one concentration (the size of the read-out at that concentration, not a potency): 41%
Beside the measured number, compound 4's estimate is 1 percentage points above it; measured number inside the range.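

On the core of compound 3, the change from tert-butyl to benzyl on an oxygen next to a carbonyl group gave, in this assay, a step of a number 15 percentage points higher from compound 3 to compound 4 (beyond the scatter), so the gain seen on the first core appeared again on the second. Set side by side, the two steps agree, and in this small series the change carried over from one core to the other at much the same size: the same change on two cores in this assay, a number 19 percentage points higher (beyond the scatter) from compound 1 to compound 2 and a number 15 percentage points higher (beyond the scatter) from compound 3 to compound 4, 4 percentage points apart, within the scatter of two such steps. For the compounds shown here, this shows only that the step held on these two cores, in a single read-out taken at one concentration; it does not show that the step would hold on any third core, it gives no measure of potency, and it does not explain why the two steps match.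

The compounds shown leave open what a longer straight chain, or a benzyl ring carrying an amine or a carboxylic acid, would do on the same oxygen. They also leave open whether the aromatic ring of benzyl is needed for the step, since a cyclohexylmethyl group, which would test this directly, is not among them.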